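Amide aryl swap on the shared core

A few compounds are considered here, and "the series" means these few. Any claim that something is new, unique, unknown or untested is made for them only; others in the source may bear on it.

Among the compounds with values here, compound 2 `O=C(Nc1cccc(-c2oc3cc(-c4ccc(F)cc4)ccc3c(=O)c2O)c1)c1cccc(F)c1` gives 15500 nM in a functional assay on HepG2 cells (Homo sapiens) for antiproliferative activity, read by CCK-8 assay, with a stated time of 72 h (on this read-out lower numbers stand for stronger inhibition and higher numbers for weaker inhibition), the higher of the two numbers so far, though its nearest neighbour compound 1 `Cc1cccc(C(=O)Nc2cccc(-c3oc4cc(-c5ccc(F)cc5)ccc4c(=O)c3O)c2)c1` gives 13500 nM and the two lie within the scatter, as a 1.1-fold higher number from compound 1 to compound 2 (0.06 log units; within the scatter) shows. Compound 3 `O=C(Nc1cccc(-c2oc3cc(-c4ccc(F)cc4)ccc3c(=O)c2O)c1)c1ccc(Cl)nc1` carries 6-chloropyridin-3-yl in place of 3-fluorophenyl on a carbonyl carbon. Within the data shown here, the only measured step concerns a different change on the same carbonyl-bound ring and stayed within the scatter; no measured step addresses the pyridine change itself. A similarly small step in this assay is therefore expected, with no direction beyond the scatter. Compound 3 is expected to give 15000 nM, between 5000 nM and 45000 nM. That estimate means a 1.0-fold lower number from compound 2 to compound 3 (0.01 log units; within the scatter).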

Compound 3, half-maximal inhibitory concentration: 4610 nM
The estimate for compound 3 lay 3.3-fold (0.51 log units) above the measured number, and the stated range ends above it.
By their numbers in this assay, from the lowest: compound 3; then compounds 1 and 2 (each within the scatter of the next).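

In this assay this place on the carbonyl carbon responds to the ring change: 6-chloropyridin-3-yl in place of 3-fluorophenyl gives a 3.4-fold lower number from compound 2 to compound 3 (0.53 log units; beyond the scatter) and in place of 3-methylphenyl gives a 2.9-fold lower number from compound 1 to compound 3 (0.47 log units; beyond the scatter). Within the data shown here, these modest steps are the first beyond the scatter here, whereas fluoro in place of methyl stayed within it. Nothing available explains the gain.

The change brings in ring nitrogen and chlorine together, so their shares stay unseparated; a pyridin-3-yl or a chlorophenyl group would divide them. On these data alone, how an amine or a carboxylic acid on this ring would read remains open.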